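From methylamino to ethylamino on the shared core

This account rests on a few compounds, and the source may have more. Where it says the series, first, only, none or still open, it means among the compounds named here.

In a functional assay on HeLa cells (Homo sapiens) for antiproliferative activity, read by MTT assay, with a stated time of 48 h (on this read-out higher numbers stand for weaker inhibition and lower numbers for stronger inhibition), compound 1 (`C=C(c1cc(OC)c(OC)c(OC)c1)c1ccc(OC)cc1NC(=O)CN`) gives 70 nM. For the measured compounds named here, compound 2 (`C=C(c1cc(OC)c(OC)c(OC)c1)c1ccc(OC)cc1NC(=O)CNC`) gives 140 nM, which lies within the scatter of the only other number. Going by the values given here, compound 3 (`C=C(c1cc(OC)c(OC)c(OC)c1)c1ccc(OC)cc1NC(=O)CNCC`) has no measurement yet in this assay.

The change from compound 2 to compound 3 is methyl in place of hydrogen on a saturated chain carbon bound to an amine nitrogen, so that methylamino becomes ethylamino. Among the compounds with values here, one measured step bears on it: a 2.0-fold higher number from compound 1 to compound 2 (0.30 log units; within the scatter), with methyl in place of hydrogen on an amine nitrogen. That step involves the same amine but a different place, and it is a single pair, so it offers only modest guidance. Within the data shown here, no ethylamino compound has been measured. No step beyond the scatter is therefore expected in this assay, with at most a slight lean towards a higher number. The expected step is a 1.4-fold higher number from compound 2 to compound 3 (0.15 log units; within the scatter), estimated to remain inside the scatter. For compound 3 the estimated value is 200 nM, with an expected range from 90 nM to 450 nM.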

Compound 3, half-maximal inhibitory concentration: 430 nM
Estimate against measurement, compound 3: 2.2-fold (0.33 log units) below, within the range that was stated.
By their numbers in this assay, from the lowest: compounds 1 and 2 (each within the scatter of the next); then compound 3.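

Working notes. In this assay, for the compounds shown here, the step of a 3.1-fold higher number from compound 2 to compound 3 (0.49 log units; beyond the scatter) is the first to pass beyond the scatter, whereas the earlier step on the amine nitrogen, a 2.0-fold higher number from compound 1 to compound 2 (0.30 log units; within the scatter), stayed inside it. Counted from the unsubstituted amine, ethyl in place of hydrogen on the amine nitrogen gives a 6.1-fold higher number from compound 1 to compound 3 (0.79 log units; beyond the scatter), so this position tolerates hydrogen or methyl on the nitrogen without a resolved difference, while ethylamino separates from both and compound 3 is the weakest of the three. The change is a single added carbon on a saturated chain carbon bound to an amine nitrogen, and no information at hand accounts for the size of this step.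

Going by these compounds alone, with only three compounds, the series does not tell whether a longer chain such as propyl or butyl on the nitrogen would move the number further in the same direction or level off. It also leaves open how a branched group such as isopropyl, a second methyl on the same nitrogen as in dimethylamino, or a cyclic amine such as pyrrolidine would compare with ethylamino on the shared core.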